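Cyanosulfanyl to 3-hydroxyprop-1-yn-1-yl from compound 1

The compounds below may be only part of what the source reports. "The series", "measured", "known", "first", "only" and "open" are said of these compounds alone.

Compound 1 `N#CSc1cn([C@H]2C[C@H](O)[C@@H](CO)O2)c(=O)[nH]c1=O`: 78900 nM
Compound 2 `COc1ccc(C(=O)/C=C/c2cc(O)nc(O)n2)cc1`: > 200000 nM (a limit)
Compound 3 `O=c1[nH]c(=O)n(C2C[C@@H](CO)[C@@H](CO)C2)cc1I`: > 200000 nM (a limit)

Going by the values given here, in an ADME assay on L1210/0 cells (Mus musculus) for cytotoxicity, with a stated time of 48 h (a lower number here means a stronger inhibitor, a higher number a weaker inhibitor), compound 1 gives the only actual number, 78900 nM. Compound 2 and compound 3 each report only a limit: the limit of > 200000 nM in this assay, at which 2 of the 3 values shown sit.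

The next compound, compound 4 `O=c1[nH]c(=O)n([C@H]2C[C@H](O)[C@@H](CO)O2)cc1C#CCO`, carries 3-hydroxyprop-1-yn-1-yl in place of cyanosulfanyl on an aromatic carbon. Among the compounds with values here, no measured pair isolates this exchange, so no shift beyond the usual scatter is expected in this assay, with only a slight lean toward weaker. The estimated 1.1-fold higher number from compound 1 to compound 4 (0.06 log units; within the scatter) is accordingly small. This expectation rests on compound 1 at 78900 nM. For compound 4 the estimated value is 90000 nM, with an expected range of 20000 nM to 200000 nM.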

Compound 4, half-maximal inhibitory concentration: > 200000 nM
Compound 4 ended at the assay's limit (the forecaster's own chance of this, stated with the estimate: 35%); at least 2.2-fold (0.34 log units) between middle value and limit.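

Going by these compounds alone, on an aromatic carbon two atoms from the ring nitrogen, 3-hydroxyprop-1-yn-1-yl in place of cyanosulfanyl gives an at least 2.5-fold higher number from compound 1 to compound 4 (0.40 log units; beyond the scatter) in this assay, the first one-place exchange and one that does not leave the value unchanged. The value of compound 4 is a limit, not a number. Most of the series now reads as a single limit: the limit of > 200000 nM in this assay, at which 3 of the 4 values shown sit.

From the compounds shown here alone, how an amine, a carboxylic acid or a longer alkyl chain on this carbon would read in this assay stays open. Going by these compounds, the true size of the step also stays open.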